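A triazole ester in place of a donor-bearing ring

The compounds below may be only part of what the source reports. "The series", "measured", "known", "first", "only" and "open" are said of these compounds alone.

Measured so far:
compound 1 `CCO/C(O)=C1\C(COCCn2nncc2C(N)=O)=NC(C)=C(C(=O)OC)C1c1cccc(Cl)c1Cl`: 15.9 nM
compound 2 `CCO/C(O)=C1\C(COCCn2cc(N)n(C)c2=O)=NC(C)=C(C(=O)OC)C1c1ccccc1Cl`: 25.1 nM
compound 3 `CCO/C(O)=C1\C(COCCn2ccnn2)=NC(C)=C(C(=O)OC)C1c1cccc(Cl)c1Cl`: 5.01 nM

All three were tested in a functional assay (aorta) with Rattus norvegicus as the target; on this read-out lower numbers stand for stronger inhibition and higher numbers for weaker inhibition. Compound 2 gives the highest of the three numbers; its gap to compound 1 is within the scatter, its gap to compound 3 is beyond it. Compound 4 `CCOC(=O)c1cn(CCOCC2=NC(C)=C(C(=O)OC)C(c3ccccc3Cl)/C2=C(\O)OCC)nn1` is not yet measured. It differs from compound 2 in one place: a group of 10 heavy atoms (5 carbon, 3 nitrogen, 2 oxygen; one five-membered aromatic ring with 3 hetero atoms) in place of a group of 8 heavy atoms (4 carbon, 3 nitrogen, 1 oxygen; one five-membered aromatic ring with 2 hetero atoms), on a saturated chain carbon, two bonds along the chain from an oxygen on a saturated carbon. Among the measured compounds shown here, no measured step covers this swap directly. The nearest comparison is a 3.2-fold lower number from compound 1 to compound 3 (0.50 log units; beyond the scatter); compound 4 carries an ethoxycarbonyl on its triazole ring, much as compound 1 carries carbamoyl, so compound 4 is expected to land between compound 3 and compound 1. A modest fall is expected: a 1.7-fold lower number from compound 2 to compound 4 (0.22 log units; within the scatter). For compound 4 the estimated value is 15 nM, with a range from 6 nM to 40 nM.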

Compound 4, half-maximal inhibitory concentration: 50.1 nM
The estimate for compound 4 lay 3.3-fold (0.52 log units) below the measured number; the whole stated range lies below it.
By their numbers in this assay, from the lowest: compound 3; then compounds 1, 2 and 4 (each within the scatter of the next, the first and the last beyond it).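

In this assay this swap gives a 2.0-fold higher number from compound 2 to compound 4 (0.30 log units; within the scatter) and so does not separate the two groups on this read-out. On this saturated chain carbon, a group with 0 hydrogen-bond donors and 10 heavy atoms serves as well as one with 1 hydrogen-bond donor and 8 heavy atoms, so this pair does not need the donor. On these data alone, whether a carboxylic acid or an amine in place of the ethoxycarbonyl would hold the read-out stays open. No measurement shown explains why the number stays within the scatter across this swap.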